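Adding a Methoxy Group and Vero Cell Tolerance

The source may report more compounds than this note shows. Statements on the series, on what has been measured and on what is new or still open speak of the compounds shown alone.

In an ADME assay on Vero cells (Chlorocebus sabaeus) for cytotoxicity, read by MTT assay, with a stated time of 72 h (a higher number here means that more compound is tolerated, a lower number that less compound is tolerated), three compounds have been measured:

compound 1, `COc1ccc(/C=C/C(=O)c2ccc(OCC(O)CNCCNc3ccnc4cc(Cl)ccc34)cc2)cc1`, gives 8030 nM;
compound 2, `COc1ccc(/C=C/C(=O)c2ccc(OCC(O)CNCCNc3ccnc4cc(Cl)ccc34)cc2)cc1OC`, gives 10200 nM;
compound 3, `COc1ccc(/C=C/C(=O)c2ccccc2OCC(=O)NCCNc2ccnc3cc(Cl)ccc23)cc1OC`, gives 5310 nM.

Compound 1 and compound 2 share a core and differ only by methoxy in place of hydrogen on an aromatic carbon. This change made a 1.3-fold higher number from compound 1 to compound 2 (0.10 log units; within the scatter). Compound 3 has a different core; how it differs from compound 1 is not broken down here. Compound 3 stands lowest of the three numbers in this assay, but its gaps to compound 1 and to compound 2 are both within the scatter, so no ordering among the three can be claimed.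

Compound 4, `COc1cc(/C=C/C(=O)c2ccccc2OCC(=O)NCCNc2ccnc3cc(Cl)ccc23)cc(OC)c1OC`, is not yet measured. It differs from compound 3 by methoxy in place of hydrogen on an aromatic carbon. This is the same kind of change as that from compound 1 to compound 2, but the surroundings differ: in compound 4 the new methoxy is also meta to a methoxy group. Because a 1.3-fold higher number from compound 1 to compound 2 (0.10 log units; within the scatter) lay within the scatter, compound 4 is expected to stay close to compound 3, giving an estimated 1.1-fold higher number from compound 3 to compound 4 (0.05 log units; within the scatter). In this assay compound 4 is therefore estimated at 6000 nM, with a likely range from 3000 nM to 12000 nM.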

Compound 4, half-maximal cytotoxic concentration: 3920 nM
Beside the measured number, compound 4's estimate is 1.5-fold (0.18 log units) above it, within the range that was stated.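

Replacing 3,4-dimethoxyphenyl with 3,4,5-trimethoxyphenyl gave a 1.4-fold lower number from compound 3 to compound 4 (0.13 log units; within the scatter) in this assay, and this step can be set beside the earlier one on the other core: the same change on two cores in this assay, a 1.3-fold higher number (0.10 log units; within the scatter) from compound 1 to compound 2 and a 1.4-fold lower number (0.13 log units; within the scatter) from compound 3 to compound 4, 1.7-fold (0.24 log units) apart, within the scatter of two such steps.

Among these compounds, on these two cores, then, methoxy in place of hydrogen on an aromatic carbon produced no step that can be told from the scatter, and the two steps cannot be told apart from each other. This does not show that the change acts identically on both cores or that the cores respond differently, since two small steps can support neither claim, and it says nothing about any other core in the series.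

The compounds shown leave open whether an amine or a carboxylic acid in place of that hydrogen would give a step beyond the scatter. They also leave open whether a longer chain joining the two halves of the molecule would alter what this methoxy change does.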